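The source may report more compounds than this note shows. Statements on the series, on what has been measured and on what is new or still open speak of the compounds shown alone.

Working notes on the series. In a functional assay on CNE-2 cells (Homo sapiens) for cytotoxicity, read by sulforhodamine B assay, with a stated time of 48 h (a lower number here means a stronger inhibitor, a higher number a weaker inhibitor), compound 1 (`COc1ccc(/C=C/C(=O)c2cccc(-c3ccc(F)cc3)c2)cc1`) gives 5550 nM. Compound 2 (`COc1cc(/C=C/C(=O)c2cccc(-c3cccc(F)c3)c2)ccc1O`) gives 5690 nM, and compound 3 (`COc1ccc(-c2cc(C(=O)/C=C/c3cc(OC)c(OC)c(OC)c3)ccc2N)cc1OC`) gives 4330 nM. Compound 1 therefore stands within the scatter of both others, and these three values cannot be ranked. For the measured compounds named here, no pair of measured compounds differs in one place only, so the data hold no direct measure of a single structural change.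

The next compound to consider is compound 4 (`COc1ccc(/C=C/C(=O)c2cccc(-c3cccc(F)c3)c2)cc1`), not yet measured. It carries 3-fluorophenyl in place of 4-fluorophenyl on an aromatic carbon, meta to a large group, and otherwise keeps the core of compound 1: 3-fluorophenyl in place of 4-fluorophenyl on an aromatic carbon. The same 3-fluorophenyl group is present in compound 2, at 5690 nM, a value within the scatter of compound 1 at 5550 nM. This is only indirect support, as the two compounds differ elsewhere too.

In this assay, no step beyond the scatter is expected, and no direction is favoured. The expected change is a 1.1-fold lower number from compound 1 to compound 4 (0.03 log units; within the scatter), which would leave the series as undifferentiated as it stands now. For compound 4 the estimated value is 5200 nM, with an expected range from 2300 nM to 11500 nM.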

Compound 4, half-maximal inhibitory concentration: 740 nM
The estimate for compound 4 lay 7.0-fold (0.85 log units) above the measured number; the whole stated range lies above it.
By their numbers in this assay, from the lowest: compound 4; then compounds 3, 1 and 2 (each within the scatter of the next).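

In this assay, for the compounds shown here, 3-fluorophenyl in place of 4-fluorophenyl gives a 7.5-fold lower number from compound 1 to compound 4 (0.88 log units; beyond the scatter), the first change that can be read in one place and the first step beyond the scatter. The two groups have the same atoms and the same counts, so this aromatic carbon, meta to a large group, responds to where the fluorine sits on the ring and not only to which atoms are present, although a single pair shows this for one core only. The 3-fluorophenyl group does not set a low number on its own, since compound 2 carries it and gives 5690 nM, while compound 4 gives 740 nM; nothing available accounts for the step in compound 4 or for this contrast.

As far as these compounds go, it remains open whether 3-chlorophenyl, 3-(trifluoromethyl)phenyl, 3-cyanophenyl or unsubstituted phenyl at this place would give a number close to that of compound 4 or to that of compound 1. From the compounds shown here alone, it is equally open whether the same exchange would give a step of similar size on the core of compound 3, which carries an amine and three methoxy groups.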